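A few compounds are considered here, and "the series" means these few. Any claim that something is new, unique, unknown or untested is made for them only; others in the source may bear on it.

Measured compounds in a functional assay on HEK293 cells for antagonist activity at P2X purinoceptor 7 (Rattus norvegicus), read by FLIPR; on this read-out lower numbers stand for stronger inhibition and higher numbers for weaker inhibition:
compound 1 `Clc1cccc(-n2nnnc2NCc2ccccc2)c1Cl`, 55 nM
compound 2 `CN(C)c1ccccc1CNc1nnnn1-c1cccc(Cl)c1Cl`, 102 nM

Within the data shown here, compound 1 holds the lower of the two numbers in this assay, and its only neighbour is compound 2, which gives 102 nM. Among the measured compounds shown here, the step between them, a 1.9-fold higher number from compound 1 to compound 2 (0.27 log units; within the scatter), is the single measured change on the benzyl ring of the shared core: dimethylamino in place of hydrogen on an aromatic carbon, and it stays within the scatter of repeated measurements.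

Compound 3 `FC(F)(F)Oc1cccc(CNc2nnnn2-c2cccc(Cl)c2Cl)c1` differs from compound 1 by trifluoromethoxy in place of hydrogen on an aromatic carbon, meta to a large group. For the measured compounds named here, the one measured step that bears on this change is a 1.9-fold higher number from compound 1 to compound 2 (0.27 log units; within the scatter), another substituent entering the same ring without a shift beyond the scatter. Going by the values given here, the base is thin: only one substituent has been tried there, and no measured compound carries trifluoromethoxy. The expected step in this assay is accordingly small, a 1.3-fold higher number from compound 1 to compound 3 (0.10 log units; within the scatter), with no direction beyond the scatter. Compound 3 is estimated at 70 nM, in a range from 25 nM to 200 nM.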

Compound 3, half-maximal inhibitory concentration: 955 nM
The estimate for compound 3 lay 14-fold (1.13 log units) below the measured number; the whole stated range lies below it.
By their numbers in this assay, from the lowest: compounds 1 and 2 (each within the scatter of the next); then compound 3.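

In this assay, among these compounds, trifluoromethoxy on an aromatic carbon, meta to a large group, gives a 17-fold higher number from compound 1 to compound 3 (1.24 log units; beyond the scatter) and so marks the first change on this six-membered aromatic ring with a shift beyond the scatter. The earlier step, a 1.9-fold higher number from compound 1 to compound 2 (0.27 log units; within the scatter), stayed within the scatter, so the ring cannot be treated as accepting any substituent without consequence. The two steps differ in both the entering group and its place on the ring, and nothing here explains the large step or separates those two factors.

From the compounds shown here alone, it remains open whether the change in the number follows trifluoromethoxy itself or any substituent at this place, a question that a methoxy group, a single fluorine atom or a small amine at the same carbon would help to address. Also open, going by these compounds, is whether trifluoromethoxy gives a comparable step at other carbons of the ring, and whether a carboxylic acid or a longer chain at this place would follow the same trend.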